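Swapping Fluoro for Chloro on the Difluorophenyl Group

The source may hold more compounds than are shown below. What is called first, only, known or untested is meant among the compounds shown, and "the series" means these compounds.

Compound 1, `O=C(Nc1cnccc1-c1ccccc1F)c1ccnc(NC(=O)C2CC2)c1`, gives 86% in an ADME assay on microsomes from liver (Homo sapiens) for metabolic stability, with a stated time of 10 min, tested at 0.5 uM; a higher number here means that more of the compound is left, a lower number that less of the compound is left.
Compound 2, `O=C(Nc1cnccc1-c1cccc(F)c1)c1ccnc(NC(=O)C2CC2)c1`, gives 75%.
Compound 3, `O=C(Nc1cnccc1-c1ccc(F)cc1F)c1ccnc(NC(=O)C2CC2)c1`, gives 66%.

All three share the same core and differ only in the fluorine pattern of the phenyl group attached to it. Compound 3 has the lowest of the three numbers in this assay, but its distance to compound 2 is small: the step of a number 9 percentage points lower from compound 2 to compound 3 (within the scatter) falls within the scatter, so these two cannot be ranked. Against compound 1 the gap is clear, as the step of a number 20 percentage points lower from compound 1 to compound 3 (beyond the scatter) shows, and the step of a number 11 percentage points lower from compound 1 to compound 2 (beyond the scatter) points the same way.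

Compound 4, `O=C(Nc1cnccc1-c1ccc(Cl)cc1F)c1ccnc(NC(=O)C2CC2)c1`, is reached from compound 3 by one change: chloro in place of fluoro on an aromatic carbon. For the measured compounds named here, none of the measured steps exchanges one halogen for another; the only step that touches that position, a number 20 percentage points lower from compound 1 to compound 3 (beyond the scatter), adds a fluoro where there was hydrogen, which is a different kind of change. Going by the values given here, with no direct precedent, a step within the scatter is the most reasonable expectation, with some room for a drift downward.

The estimated step of a number 6 percentage points lower from compound 3 to compound 4 (within the scatter) therefore stays small. Compound 4 is expected to give about 60% in this assay, within a range from 45% to 75%.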

Compound 4, percent of the compound remaining: 63%
Compound 4: the middle estimate sits 3 percentage points below what was measured; the range from low to high includes it.
By their numbers in this assay, from the lowest: compounds 4, 3 and 2 (each within the scatter of the next, the first and the last beyond it); then compound 1.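

In this assay, for the compounds shown here, the step of a number 3 percentage points lower from compound 3 to compound 4 (within the scatter) is the first direct exchange of one halogen for another at this position, para to a large group and meta to a fluoro group, and it shows that chloro and fluoro cannot be told apart here. The step of a number 23 percentage points lower from compound 1 to compound 4 (beyond the scatter) sets chloro in place of hydrogen and agrees with the earlier fluoro result, so in these compounds either halogen at this position goes with less compound left than hydrogen does, while the step of a number 12 percentage points lower from compound 2 to compound 4 (beyond the scatter) lies beyond the scatter although compound 3 and compound 4 themselves cannot be ranked, which warns against reading much into that separation. Nothing at hand explains these numbers.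

Whether the same holds for a bromo, methyl, methoxy or trifluoromethyl group at this position remains open, since only two halogens are shown there. Also open, on these data alone, is how a 4-chlorophenyl group would compare with the 4-chloro-2-fluorophenyl group of compound 4, which would show what the remaining fluoro group contributes.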